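A few compounds are considered here, and "the series" means these few. Any claim that something is new, unique, unknown or untested is made for them only; others in the source may bear on it.

Compound 1 `CCCSc1nc(N/N=C/c2ccccc2Cl)c2nnn(Cc3ccccc3)c2n1` is one of three measured compounds built on a shared core. In a functional assay on ECa-109 cells (Homo sapiens) for antiproliferative activity, read by MTT assay, with a stated time of 72 h (on this read-out lower numbers stand for stronger inhibition and higher numbers for weaker inhibition), compound 1 gives 6180 nM, the lowest of the three numbers here. Compound 3 `CCCSc1nc(N/N=C/c2c(O)ccc3ccccc23)c2nnn(Cc3ccccc3)c2n1` gives 9290 nM, and the step of a 1.5-fold higher number from compound 1 to compound 3 (0.18 log units; within the scatter) stays within the scatter. Compound 2 `C#CCSc1nc(N/N=C/c2ccc(N(C)C)cc2)c2nnn(Cc3ccccc3)c2n1` gives 31300 nM; it differs from compound 1 in two places at once, so its gap cannot be tied to a single change. Compound 4 `CCCSc1nc(N/N=C(\C)c2ccccc2O)c2nnn(Cc3ccccc3)c2n1` has not been measured; it differs from compound 1 by a group of 10 heavy atoms (8 carbon, 1 nitrogen, 1 oxygen; one six-membered aromatic ring of carbon only) in place of a group of 9 heavy atoms (7 carbon, 1 nitrogen, 1 chlorine; one six-membered aromatic ring of carbon only), on a nitrogen on an aromatic ring. Among the compounds with values here, only the step from compound 1 to compound 3 bears on this change, and it stayed within the scatter, so for compound 4 no step beyond the scatter is expected, a 1.1-fold higher number from compound 1 to compound 4 (0.05 log units; within the scatter). Compound 4 is therefore estimated at 7000 nM, between 3000 nM and 17000 nM.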

Compound 4, half-maximal inhibitory concentration: 11100 nM
Compound 4: middle estimate off by 1.6-fold (0.20 log units), on the low side, and the stated range covers the measured number.
By their numbers in this assay, from the lowest: compounds 1, 3 and 4 (each within the scatter of the next); then compound 2.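

The step of a 1.8-fold higher number from compound 1 to compound 4 (0.25 log units; within the scatter) in this assay shows that this position, on a nitrogen on an aromatic ring, accepts a second kind of group change without a shift beyond the scatter. The entering group carries a hydrogen-bond donor, which the leaving group lacks, and its oxygen replaces chlorine. No measurement offers an explanation for this result. Because the whole group changes at once, the contribution of each part cannot be separated. Going by these compounds, it also remains open whether a carboxylic acid or a nitrile on this carbon ring would stay within the scatter.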